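This account rests on a few compounds, and the source may have more. Where it says the series, first, only, none or still open, it means among the compounds named here.

Of the compounds shown here, three that share one core have been measured in a functional assay for inhibition, with Homo sapiens as the target; a higher number here means that more compound is needed for the effect, a lower number that less compound is needed. Compound 1 `CC(Cl)C(=O)Nc1ccc(C2=NNC(=O)CC2)cc1`, with 1-chloroethyl on a carbonyl carbon, gives 0.45 ug/mL. Compound 2 `CC(C)(CCl)C(=O)Nc1ccc(C2=NNC(=O)CC2)cc1`, with 1-(chloromethyl)-1-methylethyl in that place, gives 11.4 ug/mL, and the swap amounts to a 25-fold higher number from compound 1 to compound 2 (1.40 log units; beyond the scatter). Compound 3 `CCCNCC(=O)Nc1ccc(C2=NNC(=O)CC2)cc1`, with (propylamino)methyl there, gives about 46.4 ug/mL, the highest number of the three, so it needs the most compound for the effect.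

Compound 4 `CCN(CC)CC(=O)Nc1ccc(C2=NNC(=O)CC2)cc1` changes one group of compound 3: diethylamino in place of propylamino on a saturated chain carbon bound to a carbonyl carbon. This puts diethylamino in place of propylamino on a saturated chain carbon bound to a carbonyl carbon.

Among the compounds with values here, no measured step exchanges one amino group for another, so none bears on this change directly. The closest evidence is a 100-fold higher number from compound 1 to compound 3 (2.01 log units; beyond the scatter) and a 4.1-fold higher number from compound 2 to compound 3 (0.61 log units; beyond the scatter), but both replace a chlorine-bearing group with an amino one, a far larger swap than the one at hand. Compound 3, at about 46.4 ug/mL, is the only measured anchor with an amino group, so the expectation rests on it, and no step beyond the scatter is expected in this assay. The expected change is a 1.2-fold lower number from compound 3 to compound 4 (0.06 log units; within the scatter). For compound 4 the estimate is 40 ug/mL, with an expected range from 14 ug/mL to 115 ug/mL.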

Compound 4, half-maximal effective concentration: about 10 ug/mL
Compound 4: middle estimate off by 4.0-fold (0.60 log units), on the high side; the whole stated range lies above it.
By their numbers in this assay, from the lowest: compound 1; then compounds 4 and 2 (each within the scatter of the next); then compound 3.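

In this assay, within the data shown here, the amino group on a saturated chain carbon bound to a carbonyl carbon turns out to matter in its own right: diethylamino in place of propylamino gives a 4.6-fold lower number from compound 3 to compound 4 (0.67 log units; beyond the scatter) and lies beyond the scatter, whereas the earlier steps only exchanged a chlorine-bearing group for an amino one. This single change brings the amino compounds level with a chlorine-bearing one, with a 1.1-fold lower number from compound 2 to compound 4 (0.06 log units; within the scatter) staying within the scatter, but it does not close the gap to the 1-chloroethyl group, as a 22-fold higher number from compound 1 to compound 4 (1.35 log units; beyond the scatter) still shows a large step. No measurement here accounts for this shift.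

Propylamino carries a hydrogen-bond donor and diethylamino none, and the two groups also differ in their carbon count, so this one pair cannot say which of these differences goes with the lower number. Going by these compounds, whether the trend holds for other amino groups, such as ethylamino, dimethylamino or dipropylamino, remains open, as does whether any amino group can reach the low number of the 1-chloroethyl compound.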